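Methoxymethyl for Ethoxy: Expected Cytotoxicity of Compound 4

This account rests on a few compounds, and the source may have more. Where it says the series, first, only, none or still open, it means among the compounds named here.

Three compounds built on one shared core were examined in a toxicity assay on MT2 cells (Homo sapiens) for cytotoxicity, read by MTT assay; on this read-out higher numbers stand for lower toxicity in this test and lower numbers for higher toxicity in this test. Compound 1 `Cc1c(Oc2ccccc2OCCn2ccc(=O)[nH]c2=O)cc(Cl)c2ccc(C#N)cc12` carries a chloro group on the core; in this assay compound 1 reaches only the limit > 100000 nM, which is not a number. Compound 2 `CCc1cc(Oc2ccccc2OCCn2ccc(=O)[nH]c2=O)c(C)c2cc(C#N)ccc12` has an ethyl group in that place and in this assay gives 12000 nM. Compound 3 `CCOc1cc(Oc2ccccc2OCCn2ccc(=O)[nH]c2=O)c(C)c2cc(C#N)ccc12` bears an ethoxy group there; in this assay compound 3 again stops at the limit > 100000 nM, not a number. Compound 3 thus stands at the limit of > 100000 nM in this assay, at which 2 of the 3 values shown sit. The measured steps read an at least 8.3-fold lower number from compound 1 to compound 2 (0.92 log units; beyond the scatter) and an at least 8.3-fold higher number from compound 2 to compound 3 (0.92 log units; beyond the scatter), while a step that the two limits leave unreadable from compound 1 to compound 3.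

Compound 4 `COCc1cc(Oc2ccccc2OCCn2ccc(=O)[nH]c2=O)c(C)c2cc(C#N)ccc12` differs from compound 3 by methoxymethyl in place of ethoxy on an aromatic carbon. Among the compounds with values here, the steps that bear on this change are the one from the ethyl to the ethoxy compound, an at least 8.3-fold higher number from compound 2 to compound 3 (0.92 log units; beyond the scatter), and the unreadable one from the chloro compound, both ending at the limit. Since the atoms are only rejoined, a smaller move than the ethyl-to-ethoxy step is expected, so the estimated step is an at least 1.6-fold lower number from compound 3 to compound 4 (0.22 log units; that floor lies within the scatter). Compound 4 is therefore expected to give about 60000 nM in this assay, with a range from 15000 nM to 200000 nM.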

Compound 4, half-maximal cytotoxic concentration: 16000 nM
Beside the measured number, compound 4's estimate is 3.8-fold (0.57 log units) above it, and the stated range covers the measured number.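

In this assay, rejoining the same atoms on this aromatic carbon, para to a methyl group, clearly matters: methoxymethyl in place of ethoxy gives an at least 6.2-fold lower number from compound 3 to compound 4 (0.79 log units; beyond the scatter), so the read-out at this position depends on how the atoms are connected and not only on which atoms the group holds. Methoxy in place of methyl on the saturated chain carbon leaves a 1.3-fold higher number from compound 2 to compound 4 (0.12 log units; within the scatter), so the ethyl and methoxymethyl compounds, both joined through carbon, read alike, while the step from the chloro compound is an at least 6.2-fold lower number from compound 1 to compound 4 (0.79 log units; beyond the scatter), and compound 1 goes against any simple reading in which only the ethoxy group's oxygen on the aromatic carbon sets a compound apart. The readings of compound 1 and compound 3 are limits and not numbers, so both steps that start from them give only a floor: the limit of > 100000 nM in this assay, at which 2 of the 4 values shown sit.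

As far as these compounds go, how large those two steps really are stays open, as does whether the link between carbon-joined groups and a lower number extends beyond ethyl and methoxymethyl. A longer chain such as propyl, or an amine on the same aromatic carbon, would test how far that link holds.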